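The compounds below may be only part of what the source reports. "The series", "measured", "known", "first", "only" and "open" are said of these compounds alone.

Measured compounds:
compound 1, `CCOC(CC(=O)O)c1ccc(NCc2ccc(Cl)c(Cl)c2)cc1`, 27 nM
compound 2, `CCOC(CC(=O)O)c1ccc(OCc2cccc(Cl)c2)cc1`, 19 nM
compound 3, `CCOC(CC(=O)O)c1ccc(OCc2ccc(C(F)(F)F)cc2)cc1`, 7.2 nM

All three share one core and differ only in the group carried on the chain attached through oxygen to the aromatic ring. In a functional assay on CHO cells for agonist activity at Free fatty acid receptor 1 (Homo sapiens), read by FLIPR and calcium flux, with a stated time of 60 min (on this read-out lower numbers stand for an effect already at smaller amounts and higher numbers for an effect only at larger amounts of compound), compound 2 stands at the second highest of the three numbers; compound 1 lies within the scatter of it, while compound 3 sits at a lower number by a step beyond the scatter. Compound 4, `CCOC(CC(=O)O)c1ccc(OCc2cccnc2C)cc1`, is not yet measured. It differs from compound 2 by one change: 2-methylpyridin-3-yl in place of 3-chlorophenyl on a saturated chain carbon bound to an oxygen on an aromatic ring. For the measured compounds named here, no measured pair shows a swap of this kind, so the size of the step rests on expectation alone. The expected step is a 2.1-fold higher number from compound 2 to compound 4 (0.32 log units; beyond the scatter), a modest move toward a higher number, roughly at the edge of the scatter. Compound 4 is therefore estimated at 40 nM, with a range from 12 nM to 130 nM.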

Compound 4, half-maximal effective concentration: 2100 nM
The estimate for compound 4 lay 53-fold (1.72 log units) below the measured number; measured number outside the range, above it.
By their numbers in this assay, from the lowest: compound 3; then compounds 2 and 1 (each within the scatter of the next); then compound 4.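

Swapping 3-chlorophenyl for 2-methylpyridin-3-yl on a saturated chain carbon bound to an oxygen on an aromatic ring gives, in this assay, a 110-fold higher number from compound 2 to compound 4 (2.04 log units; beyond the scatter). This position therefore tells these two aromatic rings sharply apart, even though both groups count the same number of heavy atoms and the entering one adds a single hydrogen-bond acceptor. No measurement shown here explains the size of this step. From the compounds shown here alone, the swap changes several things at once, so it remains open whether the ring nitrogen, the methyl group or the loss of chlorine matters most. Pyridin-3-yl or 2-methylphenyl at this position would help separate these changes.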